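Morpholinyl in place of methyl on the amide nitrogen

The source may hold more compounds than are shown below. What is called first, only, known or untested is meant among the compounds shown, and "the series" means these compounds.

Measured compounds:
compound 1 `CNC(=O)c1cc2c(-c3ccccc3)ccc(OC)c2o1` 18%
compound 2 `COC(=O)Nc1cc2c(-c3ccccc3)ccc(OC)c2o1` 86%
compound 3 `CCOC(=O)c1ccc(-c2ccc(OC)c3oc(C(=O)Nc4ccccc4)cc23)cc1` "not determined" (no result reported)

In a functional assay on the whole organism for inhibition, with Mus musculus as the target, at a dose of 10 mg/kg by the oral route (on this read-out higher numbers stand for more inhibition at the one dose given (going by the name of the read-out) and lower numbers for less inhibition), compound 1 gives 18%, the lower of the two numbers in hand. Going by the values given here, compound 2 gives 86%; the single measured step, a number 68 percentage points higher from compound 1 to compound 2 (beyond the scatter), is large and beyond the scatter. Compound 3 gives "not determined" (no result reported) in this assay, so nothing can be read from it.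

Compound 4 `COc1ccc(-c2ccccc2)c2cc(C(=O)NN3CCOCC3)oc12` differs from compound 1 only at the amide: morpholin-4-yl in place of methyl on an amide-type nitrogen. Among the compounds with values here, the one measured step exchanges the methylcarbamoyl group itself for a (methoxycarbonyl)amino group and so does not test a substituent on the amide nitrogen; no measured pair bears on the change from compound 1 to compound 4. The only anchor is the low value of compound 1, and the series shows that a single change at this position can move the number far. Within the data shown here, with no step of the same kind in hand, the estimate for compound 4 is kept near compound 1 with a wide range: the expected step is a number 12 percentage points higher from compound 1 to compound 4 (beyond the scatter). Compound 4 is expected to give about 30%, most likely between 5% and 65% in this assay.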

Compound 4, a percentage reported as inhibition, in the whole organism at one dose (the size of the read-out at that dose, not a potency): 78%
Beside the measured number, compound 4's estimate is 48 percentage points below it, outside the stated range (above it).
By their numbers in this assay, from the lowest: compound 1; then compounds 4 and 2 (each within the scatter of the next).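

In this assay, a number 60 percentage points higher from compound 1 to compound 4 (beyond the scatter), so a change confined to the substituent on the amide-type nitrogen, with the carbonyl carbon kept in place, can by itself produce a large step. The earlier step replaced the whole methylcarbamoyl group with (methoxycarbonyl)amino, so it could not separate the carboxamide link from what sits on its nitrogen; this pair shows that the low number of compound 1 does not belong to that link as such. No measured evidence on the compounds bears on why the number moves at this position.

The change from methyl to morpholin-4-yl alters several things together, as the same difference also reads methylamino to (morpholin-4-yl)amino, and the compounds shown do not separate the nitrogen attached to the amide nitrogen from the ring or from the ring oxygen. Piperidin-1-yl, dimethylamino or cyclohexyl on the same nitrogen would pull these apart, and whether the step carries over to other substituents on the core of compound 1 remains open.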